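The source may report more compounds than this note shows. Statements on the series, on what has been measured and on what is new or still open speak of the compounds shown alone.

The three measured compounds share one core and differ only in the chain attached through an oxygen to the carbonyl group. Compound 1 `CC(C)CCOC(=O)OCC(CO)CCn1cnc2cnc(N)nc21` gives in a functional assay on Vero cells (Chlorocebus sabaeus) for cytotoxicity (on this read-out higher numbers stand for lower toxicity in this test and lower numbers for higher toxicity in this test), a value of 357000 nM. Compound 2 `CC(C)COC(=O)OCC(CO)CCn1cnc2cnc(N)nc21` reaches in this assay only the assay limit of > 500000 nM. Compound 3 `CCCOC(=O)OCC(CO)CCn1cnc2cnc(N)nc21` likewise reaches in this assay only the limit of > 500000 nM, so for compound 3 no number is known, only that it stands at the top of the measurable range. The steps of an at least 1.4-fold higher number from compound 1 to compound 2 (0.14 log units; that floor lies within the scatter) and an at least 1.4-fold higher number from compound 1 to compound 3 (0.14 log units; that floor lies within the scatter) are floors lying within the scatter, and the step that the two limits leave unreadable from compound 2 to compound 3 cannot be read because both of its values sit at the limit of > 500000 nM in this assay, at which 2 of the 3 values shown sit.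

Compound 4 `CC(C)OC(=O)OCC(CO)CCn1cnc2cnc(N)nc21` is the one still to be measured; it differs from compound 3 by isopropyl in place of propyl on an oxygen next to a carbonyl group. The nearest measured comparison is an at least 1.4-fold higher number from compound 1 to compound 2 (0.14 log units; that floor lies within the scatter), also a branching of the chain, and it shows nothing beyond the scatter. Every related value sits at or close to the limit, so compound 4 is expected to show no step beyond the scatter, which the estimate a number no higher from compound 3 to compound 4 (the limit leaves the size open) expresses. For compound 4 the estimated value in this assay is therefore 500000 nM, with a range from 250000 nM to 1000000 nM.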

Compound 4, half-maximal cytotoxic concentration: > 500000 nM
Compound 4: no number, only a limit (the forecaster's own chance of this, stated with the estimate: 80%); the middle value lies on the limit itself.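

Swapping propyl for isopropyl on this oxygen rearranges the same carbons, and in this assay the new compound still gives only a limit, so this change brings out no measurable cytotoxicity. The steps from compound 3 and from compound 2 to compound 4 cannot be read because each pair has limits on both sides: the limit of > 500000 nM in this assay, at which 3 of the 4 values shown sit.

Within the data shown here, the one step that gives any size is an at least 1.4-fold higher number from compound 1 to compound 4 (0.14 log units; that floor lies within the scatter), so even the pair with the largest difference in chain, isopentyl against isopropyl, is not separated beyond the usual variation.

On these data alone, how far compound 2, compound 3 and compound 4 lie past the limit remains unknown, so no order can be given among them. As far as these compounds go, it also remains open whether a longer chain such as octyl, or an amine at the end of the chain, would give a value inside the measurable range of this assay.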